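Moving the hydroxy onto a carbon arm of the pyridine

The source may report more compounds than this note shows. Statements on the series, on what has been measured and on what is new or still open speak of the compounds shown alone.

Of the compounds shown here, two have been measured so far in an assay on cells for binding affinity to Orexin receptor type 2 (Homo sapiens), read by radioligand binding; a lower number here means a stronger inhibitor, a higher number a weaker inhibitor. Compound 1 `Cc1ccc(-n2nccn2)c(C(=O)N2C[C@H](C#Cc3cccnc3)CC[C@H]2C)c1` gives 41 nM. For the measured compounds named here, compound 2 `Cc1ccc(-n2nccn2)c(C(=O)N2C[C@H](C#Cc3cccnc3O)CC[C@H]2C)c1` gives 24 nM, which is the lowest of the two numbers; the step of a 1.7-fold lower number from compound 1 to compound 2 (0.23 log units; within the scatter) is the only step measured, and it lies within the scatter, so the two compounds cannot be ranked against each other.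

Compound 3 `Cc1ccc(-n2nccn2)c(C(=O)N2C[C@H](C#Cc3cc(CO)ccn3)CC[C@H]2C)c1` is the next compound. Its change from compound 2 is 4-(hydroxymethyl)pyridin-2-yl in place of 2-hydroxypyridin-3-yl on a triple-bonded carbon. Going by the values given here, the single measured step bears on this change only in part: it shows that adding a hydroxy to the pyridine ring of compound 1 altered the number little. Nothing measured speaks to shifting the ring nitrogen or to a hydroxymethyl. The step of a 1.7-fold higher number from compound 2 to compound 3 (0.22 log units; within the scatter) is therefore expected to be small, with no clear direction. Compound 3 is estimated at 40 nM, within a range from 12 nM to 130 nM.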

Compound 3, inhibition constant: 42 nM
Estimate against measurement, compound 3: 1.1-fold (0.02 log units) below, within the range that was stated.
By their numbers in this assay, from the lowest: compounds 2, 1 and 3 (each within the scatter of the next).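

In this assay, the new result is a 1.8-fold higher number from compound 2 to compound 3 (0.24 log units; within the scatter), and against the compound without a hydroxy it is a 1.0-fold higher number from compound 1 to compound 3 (0.01 log units; within the scatter); both steps lie within the scatter, so compound 1, compound 2 and compound 3 cannot be told apart. What this adds is that the group on the triple-bonded carbon can be 4-(hydroxymethyl)pyridin-2-yl, with its different ring attachment and its hydroxy carried on a carbon arm, and still give a number that cannot be separated from those of pyridin-3-yl and 2-hydroxypyridin-3-yl. No evidence is available to explain why these three groups give such similar numbers.

The compounds shown leave open whether any group at this position gives a number beyond the scatter. An amine or a carboxylic acid on the ring, or a 2-hydroxyethyl chain in place of hydroxymethyl, would test that.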